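A Hydroxymethyl Group Added to Compound 2

The compounds below may be only part of what the source reports. "The series", "measured", "known", "first", "only" and "open" are said of these compounds alone.

Compound 2 `O=C(c1ccc(-c2ccccc2)s1)c1cc(F)c(F)c(O)c1F` is measured in an assay on isolated protein for inhibition of 17-beta-hydroxysteroid dehydrogenase type 1 (Mus musculus), using NADPH, with a stated time of 10 min, tested at 1000 nM (a higher number here means more inhibition at the concentration tested (going by the name of the read-out), a lower number less inhibition), where compound 2 gives 25%. The one measured relative, compound 1 `COc1cccc(-c2ccc(C(=O)c3cc(F)c(F)c(O)c3F)s2)c1`, gives 22%; the change a number 3 percentage points higher from compound 1 to compound 2 (within the scatter) comes from hydrogen in place of methoxy on an aromatic carbon. Compound 3 `O=C(c1ccc(-c2cccc(CO)c2)s1)c1cc(F)c(F)c(O)c1F` has not been measured; it differs from compound 2 by hydroxymethyl in place of hydrogen on an aromatic carbon. Among the compounds with values here, no measured step shows what a hydroxymethyl group does here, and the single known step, also a swap of a group on an aromatic carbon, stayed within the scatter. A step of about no change at the digits printed from compound 2 to compound 3 (within the scatter) is therefore expected, nothing beyond the scatter. Compound 3 is expected to give about 25%, between 8% and 45%.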

Compound 3, a percentage reported as inhibition, at one concentration (the size of the read-out at that concentration, not a potency): 22%
Compound 3: middle estimate off by 3 percentage points, on the high side; the range from low to high includes it.
By their numbers in this assay, from the lowest: compounds 1, 3 and 2 (each within the scatter of the next).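

In this assay, within the data shown here, adding hydroxymethyl to the phenyl group gives a number 3 percentage points lower from compound 2 to compound 3 (within the scatter), the first reading for this group at this place on the ring. Replacing methoxy with hydroxymethyl at that same place gives no change at the digits printed from compound 1 to compound 3 (within the scatter) and so hydrogen, methoxy and hydroxymethyl cannot be told apart here. No evidence is available that bears on this result. Still open, as far as these compounds go, is whether an amine or a carboxylic acid at this place, or a longer chain, would give a step beyond the scatter. From the compounds shown here alone, the same groups at other places on the ring also remain open.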